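The source may report more compounds than this note shows. Statements on the series, on what has been measured and on what is new or still open speak of the compounds shown alone.

Compound 1 `CC(=O)N1N=C(c2ccc(OCc3cn(Cc4ccc([N+](=O)[O-])cc4)nn3)cc2)CC1c1ccccc1` was tested in a functional assay on COLO 205 cells (Homo sapiens) for inhibition, read by sulforhodamine B assay, tested at 100 uM (a higher number here means more inhibition of growth at the concentration tested, a lower number less inhibition of growth), and gives 55%. Two companions have numbers in this assay as well: compound 2 `COc1cc(C2CC(c3ccc(OCc4cn(Cc5ccc([N+](=O)[O-])cc5)nn4)cc3)=NN2C(C)=O)ccc1Oc1cn(Cc2ccc([N+](=O)[O-])cc2)nn1` gives 51%, and compound 3 `COc1cc(C2CC(c3ccc(Br)cc3)=NN2C(C)=O)ccc1OCc1cn(Cc2ccc([N+](=O)[O-])cc2)nn1` gives 47%. The number for compound 1 is the highest of the three, but the gaps to compound 2 and to compound 3 both lie within the usual scatter, so the three numbers cannot be told apart with confidence.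

Compound 4 `COc1ccc(C2CC(c3ccc(OCc4cn(Cc5ccc([N+](=O)[O-])cc5)nn4)cc3)=NN2C(C)=O)cc1OC` has not been measured. It differs from compound 1 in one place: 3,4-dimethoxyphenyl in place of phenyl on a saturated ring carbon. Going by the values given here, no pair of measured compounds shows this exact step, so its size cannot be read off. What is visible is that compound 2, which carries a methoxy on the ring at that carbon alongside a larger group, gives 51%, close to compound 1. The expectation is therefore a step from compound 1 to compound 4 of a number 5 percentage points lower from compound 1 to compound 4 (within the scatter), not beyond the scatter in either direction. Compound 4 is estimated at 50%, with a range from 38% to 62%.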

Compound 4, percent growth inhibition at one concentration: 38%
Compound 4: middle estimate off by 12 percentage points, on the high side; low and high end bracket the measured number.
By their numbers in this assay, from the lowest: compounds 4, 3, 2 and 1 (each within the scatter of the next, the first and the last beyond it).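

In this assay, putting 3,4-dimethoxyphenyl in place of phenyl on the saturated ring carbon gives a number 17 percentage points lower from compound 1 to compound 4 (beyond the scatter), the first single change among these compounds whose size can be read at all. It shows that growth inhibition responds to what this carbon carries, so the position is not indifferent to substitution, at least for this one pair on the shared core. Nothing measured here explains why the larger group goes with the lower number.

As far as these compounds go, one step cannot separate the two methoxy groups, so it remains open whether a single methoxy would account for all of the step or only part of it. Also open, from the compounds shown here alone, is how a hydroxy group, a chlorine or a dimethylamino group on that phenyl ring would compare.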